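Dimethoxyphenyl for Phenyl Across Two Cores in Vero Cells

This account rests on a few compounds, and the source may have more. Where it says the series, first, only, none or still open, it means among the compounds named here.

Compound 1 `O=c1cc(NCc2ccccc2)sc2c([N+](=O)[O-])cc(C(F)(F)F)cc12` and compound 2 `COc1ccc(CNc2cc(=O)c3cc(C(F)(F)F)cc([N+](=O)[O-])c3s2)cc1OC` share one core, while compound 3 `CN(Cc1ccccc1)c1nc(=O)c2cc(C(F)(F)F)cc([N+](=O)[O-])c2o1` and compound 4 `COc1ccc(CN(C)c2nc(=O)c3cc(C(F)(F)F)cc([N+](=O)[O-])c3o2)cc1OC` share another; the difference between the two cores is not broken down here. In an ADME assay on Vero cells (Chlorocebus sabaeus) for cytotoxicity, read by MTT assay, with a stated time of 48 h (on this read-out higher numbers stand for weaker inhibition and lower numbers for stronger inhibition), compound 1 gives > 64 ug/mL, a limit of the assay rather than a number. Compound 2 likewise gives > 64 ug/mL, again only a limit. The change between them, (3,4-dimethoxyphenyl in place of phenyl on a saturated chain carbon bound to a nitrogen on an aromatic ring), therefore shows a step that the two limits leave unreadable from compound 1 to compound 2. For the measured compounds named here, compound 3 gives 3.84 ug/mL, the only number among the three. The same change, (3,4-dimethoxyphenyl in place of phenyl on a saturated chain carbon bound to a nitrogen on an aromatic ring), leads from compound 3 to compound 4. For compound 4 a small step of a 1.0-fold higher number from compound 3 to compound 4 (0.02 log units; within the scatter) is expected. That expectation rests on compound 3 with its value 3.84 ug/mL and on the unreadable step that the two limits leave unreadable from compound 1 to compound 2, which sits at the limit of > 64 ug/mL in this assay, at which 2 of the 3 values shown sit, and gives no sign of direction. Compound 4 is thus estimated at 4 ug/mL, between 1.5 ug/mL and 12 ug/mL.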

Compound 4, half-maximal inhibitory concentration: 9.46 ug/mL
Estimate against measurement, compound 4: 2.4-fold (0.37 log units) below, within the range that was stated.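

In this assay, 3,4-dimethoxyphenyl in place of phenyl gives a 2.5-fold higher number from compound 3 to compound 4 (0.39 log units; beyond the scatter), a modest step that lies beyond the scatter on the core of compound 3. This one readable step does not show that the change carries from one core to the other, since no size or direction can be compared between the two cores. The matching step on the core of compound 1 cannot be read, because compound 1 and compound 2 both sit at a limit rather than at a number: the limit of > 64 ug/mL in this assay, at which 2 of the 4 values shown sit.

The compounds shown leave open how an amine or a carboxylic acid in place of phenyl, on the same saturated chain carbon, would read in this assay on either core. They also leave open whether a longer chain bearing 3,4-dimethoxyphenyl would give a step of similar size.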